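Tert-butyl in place of chloro: expecting compound 4

A few compounds are considered here, and "the series" means these few. Any claim that something is new, unique, unknown or untested is made for them only; others in the source may bear on it.

Measured so far in a functional assay on HCT-116 cells (Homo sapiens) for antiproliferative activity, read by MTT assay, with a stated time of 72 h; on this read-out lower numbers stand for stronger inhibition and higher numbers for weaker inhibition:
- Compound 1 `CC(C)(C)NC(=O)CCc1cccc2c1B(O)OC2`: > 100000 nM (a limit of the assay)
- Compound 2 `O=C(CCc1cccc2c1B(O)OC2)Nc1nccs1`: > 100000 nM (a limit of the assay)
- Compound 3 `O=C(CCc1cccc2c1B(O)OC2)Nc1ccc(Cl)cc1`: 12000 nM

Compound 3, at 12000 nM, is the only one of the three with an actual number. Compound 1 and compound 2 stand at the limit of > 100000 nM in this assay, at which 2 of the 3 values shown sit. The series shows an at least 8.3-fold lower number from compound 1 to compound 3 (0.92 log units; beyond the scatter), and also an at least 8.3-fold lower number from compound 2 to compound 3 (0.92 log units; beyond the scatter). Between the two limits there is a step that the two limits leave unreadable from compound 1 to compound 2.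

Compound 4 `CC(C)(C)c1ccc(NC(=O)CCc2cccc3c2B(O)OC3)cc1` keeps everything in compound 3 except one group, with tert-butyl in place of chloro on an aromatic carbon. The two readable steps both change the whole group on the amide-type nitrogen, and both end at 4-chlorophenyl. Going by the values given here, neither replaces the chloro itself, so they show only that compound 3 gives a number in this assay where its two neighbours give limits. With the aromatic ring retained in compound 4, no step beyond the scatter is expected, though the uncertainty is wide and a result at the limit cannot be excluded. The estimated step is a 1.2-fold lower number from compound 3 to compound 4 (0.08 log units; within the scatter). For compound 4 the expected value is 10000 nM, with an estimated range of 3000 nM to 40000 nM.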

Compound 4, half-maximal inhibitory concentration: 19000 nM
Compound 4: middle estimate off by 1.9-fold (0.28 log units), on the low side; the measured number falls inside the stated range.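

In this assay, tert-butyl takes the place of chloro on the aromatic carbon with a 1.6-fold higher number from compound 3 to compound 4 (0.20 log units; within the scatter), the first change shown at this position rather than of the whole group on the amide-type nitrogen. The exchange of a group of 1 heavy atom for one of 4 heavy atoms, with chlorine gone and only carbon in its place, therefore leaves no step beyond the scatter, so the chlorine itself is not needed for this pair to give a readable number. Compound 3 and compound 4 thus both stand as actual numbers, apart from the two compounds that remain at a limit: the limit of > 100000 nM in this assay, at which 2 of the 4 values shown sit.

Both groups shown at this position count 0 hydrogen-bond donors and 0 hydrogen-bond acceptors, and whether an amine or a carboxylic acid there would keep the number in the same range stays open. Also open is what a longer chain between the core and the amide-type nitrogen would do, as the compounds shown all share one chain.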